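A few compounds are considered here, and "the series" means these few. Any claim that something is new, unique, unknown or untested is made for them only; others in the source may bear on it.

Compound 1 `N#Cc1ccc(-c2cnc(N)c(-c3ccc(N)nc3)n2)cc1`: > 90%
Compound 2 `Nc1ncc(-c2ccc(C(=O)N3CC(O)C3)cc2)nc1-c1ccc(C(F)(F)F)cc1`: > 90%

In an ADME assay on microsomes from liver (Rattus norvegicus) for metabolic stability, read by LC-MS, using NADPH, with a stated time of 30 min, tested at 0.1 uM, in the presence of a further agent that is not named here (on this read-out higher numbers stand for a more stable compound and lower numbers for a less stable compound), compound 1 gives > 90%, which is a limit of the assay and not a number. Compound 2 gives > 90%, also a limit. Among the measured compounds shown here, both sit at the limit of > 90% in this assay, at which 2 of the 2 values shown sit, so compound 1 stands level with the one other value shown, and no measured step tells how far a change of group moves this read-out. Compound 3 `Nc1ccc(-c2nc(-c3ccc(S(=O)(=O)C4CC4)cc3)cnc2N)cn1` carries cyclopropylsulfonyl in place of cyano on an aromatic carbon. In this assay no step beyond the usual scatter is expected, and the expected step is a number at least 2 percentage points lower from compound 1 to compound 3 (that floor lies within the scatter). For compound 3 the estimate is 88%, with a range from 70% to 98%.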

Compound 3, percent of the compound remaining: > 90%
Compound 3 was reported as a limit (the forecaster's own chance of this, stated with the estimate: 55%); middle value at least 2 percentage points away from the limit.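

Compound 1 and compound 3 both sit at a limit of this assay, not at a number, and no step can be read between them. The compounds shown leave open how far cyclopropylsulfonyl in place of cyano moves this read-out.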